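The source may report more compounds than this note shows. Statements on the series, on what has been measured and on what is new or still open speak of the compounds shown alone.

Measured so far in an assay on RBL-1 cells for inhibition of Polyunsaturated fatty acid 5-lipoxygenase (Rattus norvegicus); a higher number here means a weaker inhibitor, a lower number a stronger inhibitor:
compound 1 `O=C1NCCN(c2cccc(Cl)c2)N1`, 5300 nM;
compound 2 `CSc1cccc(N2CCNC(=O)N2)c1`, 14000 nM;
compound 3 `O=C1NCCN(c2cccc(O)c2)N1`, 32000 nM.

Compound 1 has the lowest number of the three: the steps of a 2.6-fold higher number from compound 1 to compound 2 (0.42 log units; beyond the scatter) and a 6.0-fold higher number from compound 1 to compound 3 (0.78 log units; beyond the scatter) both run upward from it, and a 2.3-fold higher number from compound 2 to compound 3 (0.36 log units; beyond the scatter) continues in the same direction. Compound 4 `CC1CN(c2cccc(Cl)c2)NC(=O)N1` differs from compound 1 by methyl in place of hydrogen on a saturated ring carbon. For the measured compounds named here, none of the measured steps touches that part of the shared core; all three exchange a group on an aromatic carbon and leave the saturated ring untouched. They give no direct guide, and with nothing pointing either way the step to compound 4 is expected to stay within the scatter. Compound 4 is therefore estimated at 5500 nM in this assay, with a range of 2000 nM to 16000 nM, which means a 1.0-fold higher number from compound 1 to compound 4 (0.02 log units; within the scatter).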

Compound 4, half-maximal inhibitory concentration: 2700 nM
For compound 4 the middle estimate is 2.0-fold (0.31 log units) above the measured one, within the range that was stated.
By their numbers in this assay, from the lowest: compounds 4 and 1 (each within the scatter of the next); then compound 2; then compound 3.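

In this assay, for the compounds shown here, the first change on the saturated ring of the shared core, methyl in place of hydrogen on a saturated ring carbon, gives a 2.0-fold lower number from compound 1 to compound 4 (0.29 log units; within the scatter) and so stays within the scatter. Unlike the three exchanges on an aromatic carbon, each of which moved beyond the scatter, this step shows that the ring carbon carries a methyl with no measurable loss or gain. No evidence shown accounts for this step.

Going by these compounds, whether an ethyl, a phenyl or a hydroxymethyl on the same carbon would be tolerated stays open. So does whether the methyl would give a similar step with hydroxy or methylsulfanyl in place of chloro.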